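Adding to the sulfate chain of a tellurium compound

The compounds below may be only part of what the source reports. "The series", "measured", "known", "first", "only" and "open" are said of these compounds alone.

Compound 1 `O=S(=O)(O)OCCCCCCCCCCCC[Se]c1ccccc1`: > 100000 nM
Compound 2 `O=S(=O)(O)OCCCCCCCC[Te]c1ccccc1`: 3950 nM

Both compounds were tested in a functional assay on RAW264.7 cells (Mus musculus) for cytotoxicity, read by MTT assay, with a stated time of 24 h; a lower number here means a stronger inhibitor, a higher number a weaker inhibitor. Within the data shown here, there, compound 2 gives 3950 nM, the only true number so far. For compound 1, > 100000 nM is a limit of the assay and not a number.

Compound 3 `O=S(=O)(O)OCCCCCCCCC[Te]c1ccccc1` has not yet been measured. It differs from compound 2 in one place: (sulfooxy)methyl in place of sulfooxy on a saturated chain carbon, eight bonds along the chain from a tellurium atom. Here, (sulfooxy)methyl stands in place of sulfooxy on a saturated chain carbon, eight bonds along the chain from a tellurium atom. Among the measured compounds shown here, no measured pair shows what this change does in this assay, so nothing points firmly in either direction, and no change beyond the usual scatter is expected. The estimated step of a 1.1-fold higher number from compound 2 to compound 3 (0.06 log units; within the scatter) is therefore small. For compound 3 the expected value is 4500 nM, with an expected range of 1800 nM to 12000 nM.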

Compound 3, half-maximal inhibitory concentration: 4670 nM
The estimate for compound 3 lay 1.0-fold (0.02 log units) below the measured number; the measured number falls inside the stated range.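

In this assay, putting (sulfooxy)methyl in place of sulfooxy on a saturated chain carbon, eight bonds along the chain from a tellurium atom, gives a 1.2-fold higher number from compound 2 to compound 3 (0.07 log units; within the scatter). Among these compounds, this is the first measured pair for this change, and it shows that one added carbon at this place does not separate the two tellurium compounds in this read-out. Nothing measured here gives a reason for this result.

Going by these compounds, whether a longer group such as 2-(sulfooxy)ethyl would behave the same way stays open, as does the effect of a carboxylic acid or an amine in place of sulfooxy. Among the compounds shown here, compound 1 gives > 100000 nM, a limit and not a number, and it differs from the tellurium compounds in more than one place, so no step to it can be read.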